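Removal of a para chloro across two cores: antiproliferative outcome

The compounds below may be only part of what the source reports. "The series", "measured", "known", "first", "only" and "open" are said of these compounds alone.

Measured compounds:
compound 1, `O=C1COc2ccc(-c3cccc(NS(=O)(=O)c4ccc(F)cc4)c3)cc2N1c1ccc(Cl)cc1`, 27800 nM;
compound 2, `O=C1COc2ccc(-c3cccc(NS(=O)(=O)c4ccc(F)cc4)c3)cc2N1c1ccccc1`, 30300 nM;
compound 3, `O=C1COc2ccc(-c3cnc4ccccc4c3)cc2N1c1ccc(Cl)cc1`, 32700 nM.

In a functional assay on HepG2 cells (Homo sapiens) for antiproliferative activity, read by MTT assay, with a stated time of 72 h (on this read-out higher numbers stand for weaker inhibition and lower numbers for stronger inhibition), compound 1 gives 27800 nM and compound 2 gives 30300 nM. The two differ by hydrogen in place of chloro on an aromatic carbon, and this made a 1.1-fold higher number from compound 1 to compound 2 (0.04 log units; within the scatter). Compound 3 gives 32700 nM in this assay. How the core of compound 3 differs from the core of compound 1 is not broken down here.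

Compound 4, `O=C1COc2ccc(-c3cnc4ccccc4c3)cc2N1c1ccccc1`, is not yet measured. It differs from compound 3 by hydrogen in place of chloro on an aromatic carbon, which is the same change as that from compound 1 to compound 2, occurring twice among the compounds shown. Since that earlier change stayed within the scatter, the step of a 1.1-fold higher number from compound 3 to compound 4 (0.03 log units; within the scatter) is expected to be of similar size, because compound 3 already sits at 32700 nM and the analogous pair showed a 1.1-fold higher number from compound 1 to compound 2 (0.04 log units; within the scatter). Compound 4 is therefore estimated at 35000 nM in this assay, with a range from 17000 nM to 70000 nM.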

Compound 4, half-maximal inhibitory concentration: > 40000 nM
Compound 4 was reported as a limit; the forecaster's own chance of this, stated with the estimate: 10%; middle value at least 1.1-fold (0.05 log units) away from the limit.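

On the second core, going from 4-chlorophenyl to phenyl gives an at least 1.2-fold higher number from compound 3 to compound 4 (0.08 log units; that floor lies within the scatter) in this assay. Set beside the same change on the first core, the comparison can be taken only this far: the same change on two cores in this assay, a 1.1-fold higher number (0.04 log units; within the scatter) from compound 1 to compound 2 and an at least 1.2-fold higher number (0.08 log units; that floor lies within the scatter) from compound 3 to compound 4; the limit leaves it open whether they differ. The two steps therefore give no sign that the change behaves differently from one core to the other, but they do not show that it carries over with the same size, since compound 4 is a limit and not a number: the limit of > 40000 nM in this assay, at which 1 of the 4 values shown sits.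

The compounds shown leave open what other groups would do in place of the chloro on this aromatic ring, for instance a methoxy group, an amine or a carboxylic acid. They also leave open how far the step on the second core reaches beyond its floor, and whether the change from chloro to hydrogen would stay this small on a third core.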